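Notes on 1-benzothiophen-2-yl in place of 5-methylfuran-2-yl

This account rests on a few compounds, and the source may have more. Where it says the series, first, only, none or still open, it means among the compounds named here.

Compound 1 `Cc1ccc(-c2nc(CNc3ccc(C(=O)NO)cc3)n(-c3ccccc3)n2)o1` stands highest of the three numbers in an assay on Sf9 cells for inhibition of protein deacetylase HDAC6 (Homo sapiens), read by fluorescence, with a stated time of 40 min, tested at 100 nM (a lower number here means less inhibition, a higher number more inhibition at the concentration tested (going by the name of the read-out)), where compound 1 gives 60.7%. Compound 3 `Cc1cc(C)cc(-n2nc(-c3ccccc3)nc2CNc2ccc(C(=O)NO)cc2)c1` is nearest to it and gives 49.8% in this assay, a gap beyond the scatter. Compound 2 `Nc1ccccc1NC(=O)c1ccc(NCc2nc(-c3ccccc3)nn2-c2ccccc2)cc1` is furthest and gives 5% in this assay. No pair of these compounds differs in one place, so no single step is on hand. Compound 4 `O=C(NO)c1ccc(NCc2nc(-c3cc4ccccc4s3)nn2-c2ccccc2)cc1` is not yet measured; it differs from compound 1 by 1-benzothiophen-2-yl in place of 5-methylfuran-2-yl on an aromatic carbon. With no step of this kind in this assay to lean on, the change is expected to move inhibition only modestly, with a number 5.7 percentage points lower from compound 1 to compound 4 (within the scatter) as the expected step. Compound 4 is estimated at 55%, within 35% to 75%.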

Compound 4, a percentage reported as inhibition, at one concentration (the size of the read-out at that concentration, not a potency): 65.5%
Beside the measured number, compound 4's estimate is 10.5 percentage points below it; low and high end bracket the measured number.
By their numbers in this assay, from the lowest: compound 2; then compound 3; then compounds 1 and 4 (each within the scatter of the next).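

At this position, on an aromatic carbon between two ring nitrogen atoms, the change in this assay gives a number 4.8 percentage points higher from compound 1 to compound 4 (within the scatter) and so leaves the two compounds level. The fused 1-benzothiophen-2-yl, with 9 heavy atoms against 6 for 5-methylfuran-2-yl, therefore brings no loss of inhibition beyond the scatter at the concentration tested. No measurement shown gives a reason for this. Going by these compounds, whether an amine or a carboxylic acid at this position would hold the inhibition remains open. The single-concentration read-out also leaves open any difference in potency between compound 1 and compound 4.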